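Swapping the chlorobenzyl group on compound 2

This account rests on a few compounds, and the source may have more. Where it says the series, first, only, none or still open, it means among the compounds named here.

- compound 1 `CC1CCN(Cc2ccc3nc(NC(=O)N/N=C/c4cn(Cc5cccc(Cl)c5)c5ccccc45)sc3c2)CC1` gives 2810 nM
- compound 2 `CCN(CC)Cc1ccc2nc(NC(=O)N/N=C/c3cn(Cc4ccc(Cl)cc4Cl)c4ccccc34)sc2c1` gives 1900 nM

Both values come from a functional assay on A549 cells (Homo sapiens) for cytotoxicity, read by MTT assay, with a stated time of 72 h (on this read-out lower numbers stand for stronger inhibition and higher numbers for weaker inhibition), and lie within the usual scatter of each other, so compound 2 stands level with compound 1 on these numbers. Compound 3 `CCN(CC)Cc1ccc2nc(NC(=O)N/N=C/c3cn(Cc4cccc(Cl)c4)c4ccccc34)sc2c1` departs from compound 2 in one place: 3-chlorophenyl in place of 2,4-dichlorophenyl on a saturated chain carbon bound to an aromatic nitrogen (the same difference read one bond further out is 2,4-dichlorobenzyl to 3-chlorobenzyl). Within the data shown here, no measured pair isolates this change. Among the measured compounds shown here, the only guide is that compound 1 (at 2810 nM) already carries the 3-chlorobenzyl group. In this assay no step beyond the scatter is expected, and the estimated change is a 1.2-fold higher number from compound 2 to compound 3 (0.08 log units; within the scatter) as the working figure. For compound 3 the estimated value is 2300 nM with an expected range of 1100 nM to 4800 nM in this reading.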

Compound 3, half-maximal inhibitory concentration: 2410 nM
Compound 3: middle estimate off by 1.0-fold (0.02 log units), on the low side, within the range that was stated.
By their numbers in this assay, from the lowest: compounds 2, 3 and 1 (each within the scatter of the next).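

In this assay the step from 2,4-dichlorobenzyl to 3-chlorobenzyl, on a saturated chain carbon bound to an aromatic nitrogen, can now be read directly: a 1.3-fold higher number from compound 2 to compound 3 (0.10 log units; within the scatter) leaves this change inside the scatter. Among these compounds, the amine place can also be read for the first time, with diethylamino in place of 4-methylpiperidin-1-yl on a saturated chain carbon bound to an aromatic carbon: a 1.2-fold lower number from compound 1 to compound 3 (0.07 log units; within the scatter) likewise stays inside the scatter, so neither change separates the compounds in this assay. No measurement shown here offers a reason for either result.

On these data alone, whether an unsubstituted benzyl group or a morpholine in the amine place would give a step beyond the scatter stays open. Compound 1 and compound 2 differ in two places, so these figures do not show whether the two changes act independently.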